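A few compounds are considered here, and "the series" means these few. Any claim that something is new, unique, unknown or untested is made for them only; others in the source may bear on it.

Compound 2, with structure `Cc1nn(C)c2c1C(c1ccccc1)=NCC(=O)N2`, sits at the upper middle of the three numbers recorded so far in a functional assay on the whole organism with Rattus norvegicus as the target; on this read-out higher numbers stand for an effect only at larger amounts of compound and lower numbers for an effect already at smaller amounts: in this assay compound 2 gives 16 mg/kg. Compound 1, with structure `Cn1ncc2c1NC(=O)CN=C2c1ccccc1`, gives 250 mg/kg in this assay, and the step of a 16-fold lower number from compound 1 to compound 2 (1.19 log units; beyond the scatter) is a large one. Compound 3, with structure `CCc1nn(C)c2c1C(c1ccccc1)=NCC(=O)N2`, gives 8 mg/kg in this assay, and the step of a 2.0-fold lower number from compound 2 to compound 3 (0.30 log units; within the scatter) falls inside the usual scatter, while a 31-fold lower number from compound 1 to compound 3 (1.49 log units; beyond the scatter) does not.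

Compound 4, with structure `Cc1nn(C)c2c1C(c1ccccc1Cl)=NCC(=O)N2`, differs from compound 2 in one place: chloro in place of hydrogen on an aromatic carbon. Within the data shown here, none of the measured steps touches this position; all three concern the group on the aromatic carbon of the shared core, and so they speak only indirectly to what a change on the phenyl ring might do. In the absence of a direct precedent, a modest move in this assay is expected, with a wide margin of doubt. Compound 4 is estimated to give 5 mg/kg in this assay, within a range from 1 mg/kg to 20 mg/kg, which would mean the step of a 3.2-fold lower number from compound 2 to compound 4 (0.51 log units; beyond the scatter) is expected.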

Compound 4, minimum effective dose: 16 mg/kg
Estimate against measurement, compound 4: 3.2-fold (0.51 log units) below; the range from low to high includes it.
By their numbers in this assay, from the lowest: compounds 3, 2 and 4 (each within the scatter of the next); then compound 1.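

Chloro on an aromatic carbon of the six-membered aromatic ring of carbon only, ortho to a large group, gives no change at the digits printed from compound 2 to compound 4 (within the scatter) in this assay, so this position takes the one chlorine atom without a shift beyond the scatter. Among these compounds, the earlier compounds spoke only to the group on the aromatic carbon of the shared core, where a 16-fold lower number from compound 1 to compound 2 (1.19 log units; beyond the scatter) stands as a large step, whereas this is the only reading on the ring that carries the chloro. Nothing at hand accounts for the absence of a shift at this position.

Going by these compounds, whether a fluoro, a methoxy, a nitro or an amine at this position would leave the number equally unmoved stays open. So does whether chloro would do the same on another carbon of that ring, or with the ethyl group of compound 3 in the core.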